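Two Amides on the Core of Compound 2, Third Untested

The source may report more compounds than this note shows. Statements on the series, on what has been measured and on what is new or still open speak of the compounds shown alone.

Compound 1 `O=C(Cn1cc(-c2ccc([N+](=O)[O-])cc2)nn1)Nc1nccs1`: 1040 nM
Compound 2 `COc1cccc(-c2cn(-c3ccc(C(F)(F)F)cc3)nc2C(=O)N2CCN(c3ncccn3)CC2)c1`: > 30000 nM

In a functional assay on BMDM cells (Mus musculus, strain C57BL/6) for inhibition, with a stated time of 2 days (a lower number here means a stronger inhibitor, a higher number a weaker inhibitor), compound 1 gives 1040 nM. Compound 2 gives only a limit in this assay, > 30000 nM, so no exact number is known for it; it sits at the limit of > 30000 nM in this assay, at which 1 of the 2 values shown sits. Compound 3 `COc1cccc(-c2cn(-c3ccc(C(F)(F)F)cc3)nc2C(=O)NCCCN(C)C)c1` keeps the core of compound 2 and changes one group: (3-(dimethylamino)propyl)amino in place of 4-(pyrimidin-2-yl)piperazin-1-yl on a carbonyl carbon. Going by the values given here, no measured pair shows what such a swap does, so the step is expected to be small, likely within the scatter of this assay. Compound 3 is therefore expected near 25000 nM, between 5000 nM and 100000 nM, a step of an at least 1.2-fold lower number from compound 2 to compound 3 (0.07 log units; that floor lies within the scatter).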

Compound 3, half-maximal inhibitory concentration: > 30000 nM
Compound 3: no number, only a limit; the forecaster's own chance of this, stated with the estimate: 60%; middle value at least 1.2-fold (0.07 log units) from the limit.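

Going by these compounds alone, compound 2 and compound 3 both give only a limit in this assay, so no step between them can be read. The compounds shown leave open whether any group on that carbonyl carbon gives an exact number on the shared core.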